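A few compounds are considered here, and "the series" means these few. Any claim that something is new, unique, unknown or untested is made for them only; others in the source may bear on it.

Compound 1 `Nc1ccccc1NC(=O)c1ccc(CNC(=O)c2cc3cccnc3[nH]2)cc1` is the starting point. In a functional assay on MDA-MB-231 cells (Homo sapiens) for cytotoxicity, read by MTT assay, with a stated time of 72 h (a higher number here means a weaker inhibitor, a lower number a stronger inhibitor), compound 1 gives > 100000 nM, which is a limit of the assay and not a number. Compound 4 `Nc1ccccc1NC(=O)c1ccc(CNC(=O)c2cc3cnccc3[nH]2)cc1` has the same atoms as compound 1, joined differently: a group of 9 heavy atoms (7 carbon, 2 nitrogen; one five-membered aromatic ring with 1 hetero atom, one six-membered aromatic ring with 1 hetero atom) in place of a group of 9 heavy atoms (7 carbon, 2 nitrogen; one five-membered aromatic ring with 1 hetero atom, one six-membered aromatic ring with 1 hetero atom), on a carbonyl carbon. Among the measured compounds shown here, only two other compounds can guide an expectation. Compound 2 `Nc1ccccc1NC(=O)c1ccc(NC(=S)NCc2ccc(Cl)nc2)cc1` gives 42000 nM in this assay. Compound 3 `Nc1ccccc1NC(=O)c1ccc(NC(=S)NCc2ccccc2F)cc1` gives > 100000 nM, and this too is a limit. For the measured compounds named here, the one measured step is an at least 2.3-fold higher number from compound 2 to compound 3 (0.37 log units; beyond the scatter), with 2-fluorophenyl in place of 6-chloropyridin-3-yl. That step is modest, and it concerns a different group from the one changed here, so it bears on this change only loosely. The broader guide is the limit of > 100000 nM in this assay, at which 2 of the 3 values shown sit. No step beyond the scatter is therefore expected, and the estimated step is a number no higher from compound 1 to compound 4 (the limit leaves the size open). Compound 4 is estimated at 100000 nM, with an expected range from 40000 nM to 200000 nM.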

Compound 4, half-maximal inhibitory concentration: 48000 nM
For compound 4 the middle estimate is 2.1-fold (0.32 log units) above the measured one; the range from low to high includes it.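

Among the compounds shown, this is the first step at the group on a carbonyl carbon, and in this assay it reads as an at least 2.0-fold lower number from compound 1 to compound 4 (0.31 log units; beyond the scatter). The group that leaves and the group that enters match in every count given for them, so how the same atoms are joined within this group is enough to move the read-out beyond the usual scatter. Compound 1 gives > 100000 nM, which is a limit of the assay and not a number.

The true size of the step stays open, because it starts from a limit: the limit of > 100000 nM in this assay, at which 2 of the 4 values shown sit. Whether an amine or a carboxylic acid added to this group would lower the number further cannot be told from the compounds shown.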